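Adding dimethylamino to the ethyl chain of compound 3

The compounds below may be only part of what the source reports. "The series", "measured", "known", "first", "only" and "open" are said of these compounds alone.

Values in a functional assay on NCI-H460 cells (Homo sapiens) for inhibition, with a stated time of 72 h (a higher number here means a weaker inhibitor, a lower number a stronger inhibitor), so far:
- compound 1 `COc1cc(C(=O)c2ccc3cc[nH]c3c2)cc(OC)c1OC` gives 520 nM here
- compound 2 `COc1cc(C(=O)c2cccc3cc[nH]c23)cc(OC)c1OC` gives 295 nM here
- compound 3 `CCn1ccc2cc(C(=O)c3cc(OC)c(OC)c(OC)c3)ccc21` gives 38 nM here

Compound 3 has the lowest number of the three, and its gaps to compound 2 and to compound 1 both lie beyond the scatter. Going by the values given here, it is also the only one of the three with an ethyl group on the aromatic nitrogen, but no measured pair isolates that group.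

Compound 4 `COc1cc(C(=O)c2ccc3c(ccn3CCN(C)C)c2)cc(OC)c1OC` has not yet been measured in this assay and differs from compound 3 by dimethylamino in place of hydrogen on a saturated chain carbon, two bonds along the chain from an aromatic nitrogen on a saturated chain carbon, two bonds along the chain from an aromatic nitrogen. Ethyl thus becomes 2-(dimethylamino)ethyl.

Among the compounds with values here, no measured pair shows this change, so the expectation is loose. With compound 3 at 38 nM as the only close reference, a modest rise in the number is expected, possibly not beyond the scatter. The estimate implies a 1.8-fold higher number from compound 3 to compound 4 (0.27 log units; within the scatter) as the expected step. For compound 4 the estimated value is 70 nM with an expected range from 20 nM to 250 nM in this series.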

Compound 4, half-maximal inhibitory concentration: 5100 nM
For compound 4 the middle estimate is 73-fold (1.86 log units) below the measured one, outside the stated range (above it).
By their numbers in this assay, from the lowest: compound 3; then compounds 2 and 1 (each within the scatter of the next); then compound 4.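

In this assay, the chain on the aromatic nitrogen proves highly sensitive to substitution at its far carbon: ethyl to 2-(dimethylamino)ethyl gives a 130-fold higher number from compound 3 to compound 4 (2.13 log units; beyond the scatter). The earlier compounds shown here offered no pair that read this position, and this first step shows that a single added dimethylamino can remove most of the activity seen with the ethyl group. No measurement shown here accounts for this loss.

Going by these compounds, it remains open whether the loss is specific to dimethylamino or would also appear with another group on the same chain, such as a hydroxyl, a morpholine or a carboxylic acid. Also open, on these data alone, is how a longer chain carrying the same amine, or a plain propyl group in place of ethyl, would read at this position.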